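The source may report more compounds than this note shows. Statements on the series, on what has been measured and on what is new or still open speak of the compounds shown alone.

Working notes on the series, read in a functional assay on Caco-2 cells (Homo sapiens) for antiproliferative activity, with a stated time of 48 h; a lower number here means a stronger inhibitor, a higher number a weaker inhibitor. Among the compounds with values here, compound 2 `CC(=O)c1ccc(-c2ccc(N3CCCC3)nn2)cc1` gives 50000 nM, the only number in the set. Compound 1 `CCN(CC)c1ccc(-c2cccc(OC)c2)nn1` gives > 25000 nM, which is a limit. Compound 3 `CCN(CC)c1ccc(-c2cccc(C#N)c2)nn1` gives > 25000 nM, which is also a limit.

Compound 4 `CCN(CC)c1ccc(-c2ccc(C(C)=O)cc2)nn1` differs from compound 2 at one place: diethylamino in place of pyrrolidin-1-yl on an aromatic carbon, with diethylamino in place of pyrrolidin-1-yl on an aromatic carbon. Within the data shown here, the one measured step in the set is a step that the two limits leave unreadable from compound 1 to compound 3. It is a change of cyano in place of methoxy elsewhere on the molecule, and it gives no size to carry over. Among the measured compounds shown here, no measured step covers the exchange of diethylamino for pyrrolidin-1-yl. Compound 1 and compound 3 both carry diethylamino, and their readings are the limit of > 25000 nM in this assay, at which 2 of the 3 values shown sit. That limit does not set them apart from compound 2.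

The expected no change at the digits printed from compound 2 to compound 4 (within the scatter) in this assay therefore stays within the scatter, in neither direction. Compound 4 may equally be reported only as a limit. The estimate for compound 4 is 50000 nM, with an expected range from 25000 nM to 100000 nM.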

Compound 4, half-maximal inhibitory concentration: 15000 nM
Estimate against measurement, compound 4: 3.3-fold (0.52 log units) above; the whole stated range lies above it.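

In this assay, within the data shown here, the exchange on the aromatic carbon next to the ring nitrogen gives the first readable size for this position, a 3.3-fold lower number from compound 2 to compound 4 (0.52 log units; beyond the scatter), and this is the only step in the set that carries a size. Pyrrolidin-1-yl and diethylamino have the same heavy-atom, donor and acceptor counts and no net charge, so what the counts separate here is a five-membered non-aromatic ring against an open amine with no ring, and the open amine gives the stronger reading in this pair. Compound 4 also shows that a diethylamino compound in this set can give a number, whereas the other two diethylamino compounds are reported only as a limit: the limit of > 25000 nM in this assay, at which 2 of the 4 values shown sit.

As far as these compounds go, the step between those two limit compounds cannot be read, so it is unknown whether the effect of the amine exchange carries over to a methoxy or cyano partner in place of the acetyl group. Also open, from the compounds shown here alone, is how the reading moves with other amines at this position, such as dimethylamino, piperidin-1-yl or morpholin-4-yl, or with a carboxylic acid in place of the acetyl group.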